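The source may report more compounds than this note shows. Statements on the series, on what has been measured and on what is new or still open speak of the compounds shown alone.

In a functional assay on BV-2 cells (Mus musculus) for inhibition, read by Griess assay, with a stated time of 24 h (on this read-out lower numbers stand for stronger inhibition and higher numbers for weaker inhibition), the compounds here were compared as inhibitors, and most of them barely register.

Compound 2 `C=CCc1ccc(O)c(-c2cc(CO)on2)c1` carries a free hydroxy group on its shared core. In this assay compound 2 reaches only the limit of > 200000 nM, which is a limit of the assay and not a number. Compound 1 `C=CCc1ccc(OC)c(-c2cc(CO)on2)c1` differs from it by methyl in place of hydrogen on an oxygen on an aromatic ring. In this assay compound 1 also reaches only the limit of > 200000 nM. The step from compound 2 to compound 1 is therefore a step that the two limits leave unreadable from compound 2 to compound 1, since both values sit at the limit of > 200000 nM in this assay, at which 2 of the 3 values shown sit.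

Compound 3 `C=CCn1ccc(-c2cc(Br)ccc2O)n1` has a different core; how its core differs from that of compound 2 is not broken down here. Within the data shown here, it is the only compound with a real number: in this assay compound 3 gives 112000 nM.

Compound 4 `C=CCn1ccc(-c2cc(Br)ccc2OC)n1` has not yet been measured. It differs from compound 3 by methyl in place of hydrogen on an oxygen on an aromatic ring, the same change as that from compound 2 to compound 1, at the same kind of place. That earlier change could not be read because both ends sat at a limit, so it gives no guide to its size. Resting on the weak value of compound 3 alone, the step from compound 3 to compound 4 is expected to be a 1.6-fold higher number from compound 3 to compound 4 (0.21 log units; within the scatter), a change within the usual scatter. Compound 4 is thus expected to give about 180000 nM, somewhere between 60000 nM and 400000 nM, with a real chance that only a limit is reported.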

Compound 4, half-maximal inhibitory concentration: > 200000 nM
Compound 4: a limit, no number; the forecaster's own chance of this, stated with the estimate: 50%; middle value at least 1.1-fold (0.04 log units) from the limit.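

In this assay, replacing hydroxy with methoxy on the core of compound 3 gives an at least 1.7-fold higher number from compound 3 to compound 4 (0.25 log units; that floor lies within the scatter), so this step has only a floor, and because that floor lies within the scatter, it does not establish a real loss of inhibition. The same change on the core of compound 2 cannot be read, so there are no two sizes to set side by side, and nothing shows whether the change acts alike on both cores; the only shared observation is that neither methoxy compound, compound 1 or compound 4, gives a number. The comparison between cores stays this thin because nearly every result rests at one limit: the limit of > 200000 nM in this assay, at which 3 of the 4 values shown sit.

The compounds shown leave open what a group other than methyl would do on that oxygen, such as a longer chain like ethyl or a chain ending in an amine or a carboxylic acid. They also leave open how large this change is on a core whose hydroxy compound inhibits more strongly than compound 3. Among these compounds, compound 3, at 112000 nM, is the only compound here with a real number.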